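Changing the Amide Headgroup of Compound 1

The compounds below may be only part of what the source reports. "The series", "measured", "known", "first", "only" and "open" are said of these compounds alone.

Compound 1 `COc1ncc(C(=O)NC2(C(=O)N[C@H](C)c3ccc(-n4nc(Cl)c5ccccc54)cc3F)CC2)s1` is an amide built around a shared core, and in an in vivo ADME assay on the whole organism (strain Mongrel) for metabolic stability, with Canis familiaris (Canis lupus familiaris) as the target (a lower number here means that the compound disappears faster, a higher number that the compound lasts longer), compound 1 gives 8.3 h. Compound 2 `C[C@@H](NC(=O)C1(NC(=O)c2ccc(Br)nc2)CC1)c1ccc(-n2nc(Cl)c3ccccc32)cc1F` gives 7.1 h in this assay, and compound 3 `C[C@@H](NC(=O)C1(NC(=O)c2cncc(Cl)c2)CC1)c1ccc(-n2nc(Cl)c3ccccc32)cc1F` gives 6 h. Compound 1 therefore has the highest of the three numbers, but its separation from the others is small: a 1.2-fold lower number from compound 1 to compound 2 (0.07 log units; within the scatter) and a 1.4-fold lower number from compound 1 to compound 3 (0.14 log units; within the scatter), both within the usual scatter, so the three compounds cannot be placed in a reliable order. Compound 4 `COc1cc(C(=O)NC2(C(=O)N[C@H](C)c3ccc(-n4nc(Cl)c5ccccc54)cc3F)CC2)on1` differs from compound 1 in a single place: 3-methoxy-1,2-oxazol-5-yl in place of 2-methoxy-1,3-thiazol-5-yl on a carbonyl carbon. The two measured steps away from compound 1 bear directly on this change, since each of them also replaced the 2-methoxy-1,3-thiazol-5-yl group on the carbonyl carbon with a different aromatic ring, and in both cases the half-life hardly moved. Nothing in these data suggests that the new ring should behave differently, so the step is expected to stay within the scatter. Compound 4 is accordingly expected to give about 7 h, with a likely range from 3.5 h to 14 h. The expected step of a 1.2-fold lower number from compound 1 to compound 4 (0.07 log units; within the scatter) would thus be too small to count as a real change.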

Compound 4, half-life: 20.8 h
Beside the measured number, compound 4's estimate is 3.0-fold (0.47 log units) below it; the measured number lies above the stated range.
By their numbers in this assay, from the lowest: compounds 3, 2 and 1 (each within the scatter of the next); then compound 4.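

At this position, on a carbonyl carbon whose other neighbours are an amide-type nitrogen, the choice of ring can move the result in this assay: the change gives a 2.5-fold higher number from compound 1 to compound 4 (0.40 log units; beyond the scatter) and sets compound 4 apart from both pyridine compounds, with a 3.5-fold higher number from compound 3 to compound 4 (0.54 log units; beyond the scatter) and a 2.9-fold higher number from compound 2 to compound 4 (0.47 log units; beyond the scatter), whereas the steps among compounds 1, 2 and 3 all stayed within the scatter. The change itself is a close one, as 2-methoxy-1,3-thiazol-5-yl and 3-methoxy-1,2-oxazol-5-yl are both five-membered aromatic rings with the same counts of heavy atoms, hydrogen-bond donors and hydrogen-bond acceptors, so these counts alone do not separate compound 4 from compound 1. No measurement here explains why the half-life of compound 4 stands apart.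

The compounds shown leave open whether this longer half-life belongs to the 1,2-oxazole ring alone or also needs its methoxy group, a question that a 3-methyl-1,2-oxazol-5-yl or a 3-ethoxy-1,2-oxazol-5-yl group on the same carbonyl carbon could address. They also leave open whether the same ring change would have a similar effect on a core other than the one shared here.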